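One stereocentre, drawn or left undrawn

This account rests on a few compounds, and the source may have more. Where it says the series, first, only, none or still open, it means among the compounds named here.

Measured values in a functional assay on HCT-116 cells (Homo sapiens) for antiproliferative activity, read by MTT assay, with a stated time of 48 h (a higher number here means a weaker inhibitor, a lower number a stronger inhibitor), are as follows
Compound 1 `CCCC(CCO)n1cnc2c(Cl)ncnc21` gives > 50000 nM
Compound 2 `CCCCCCCCC(CCO)n1cnc2c(Cl)nc(F)nc21` gives 24200 nM
Compound 3 `CCCCCCCC[C@@H](CCO)n1cnc2c(Cl)ncnc21` gives 3400 nM

Compound 1 is reported only as a limit of the assay (> 50000 nM). Of the two true numbers, compound 3 at 3400 nM has the lower, and so the stronger result, against compound 2 at 24200 nM. The gap between these two compounds lies beyond the usual scatter.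

The next compound, compound 4 `CCCCCCCCC(CCO)n1cnc2c(Cl)ncnc21`, changes no connection at all: the two compounds have the same atoms and bonds; at least one stereo element is drawn with a configuration in one of them and without one in the other: 1 of 1 stereo elements differ; a stereocentre at a saturated chain carbon is drawn S in compound 3 and without a configuration in compound 4. A stereocentre is an atom whose surroundings can be arranged in two mirror-image ways. Here, a stereocentre at a saturated chain carbon is drawn S in compound 3 and without a configuration in compound 4.

Going by the values given here, no measured pair shows what such a change does. With atoms and bonds the same, the expected result in this assay stays close to compound 3 at 3400 nM and no shift beyond the scatter is anticipated. The expected step of a 1.2-fold higher number from compound 3 to compound 4 (0.07 log units; within the scatter) is an estimate that could go either way. The estimate for compound 4 is 4000 nM, with an expected range from 2000 nM to 8000 nM.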

Compound 4, half-maximal inhibitory concentration: 1650 nM
The estimate for compound 4 lay 2.4-fold (0.38 log units) above the measured number; the whole stated range lies above it.
By their numbers in this assay, from the lowest: compound 4; then compound 3; then compound 2. At a limit, above all of these: compound 1.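

In this assay, a change in the drawn configuration alone comes with a modest shift, a 2.1-fold lower number from compound 3 to compound 4 (0.31 log units; beyond the scatter), so the stereocentre on this saturated chain carbon may matter, though the pair differs only in this: the fact that one of compounds 3 and 4 is drawn with a defined configuration and the other without, at the place where they differ

The two structural changes give larger steps: hydrogen in place of fluoro on an aromatic carbon gives a 15-fold lower number from compound 2 to compound 4 (1.17 log units; beyond the scatter), and pentyl in place of hydrogen on a saturated chain carbon gives an at least 30-fold lower number from compound 1 to compound 4 (1.48 log units; beyond the scatter).

The value for compound 1 is a limit, so its step has no exact size: the limit of > 50000 nM in this assay, at which 1 of the 4 values shown sits.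

Going by these compounds, it remains open how the opposite configuration at this carbon would read, and which arrangement or arrangements the undrawn centre of compound 4 represents. Also open, on these data alone, is whether a longer chain at this carbon, or an amine in place of the chloro group, would lower the number further.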